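A few compounds are considered here, and "the series" means these few. Any claim that something is new, unique, unknown or untested is made for them only; others in the source may bear on it.

Compound 3 `Fc1ccccc1-c1cn2ccnc2c(-c2ccc3ncn(C4CCCCC4)c3c2)n1` is one of three closely related compounds measured in a functional assay on HL-60 cells (Homo sapiens) for inhibition, read by sulforhodamine B assay, with a stated time of 48 h, tested at 10 uM; a lower number here means less inhibition, a higher number more inhibition at the concentration tested (going by the name of the read-out). In this assay compound 3 gives 9.3%, which places it at the low end of the three numbers, yet the steps to the other two fall within the scatter: a number 8.7 percentage points lower from compound 1 to compound 3 (within the scatter) and a number 6.3 percentage points lower from compound 2 to compound 3 (within the scatter). Compound 1 `Brc1cn2ccnc2c(-c2ccc3ncn(C4CCCCC4)c3c2)n1` gives 18% in this assay, and compound 2 `Clc1ccc(-c2cn3ccnc3c(-c3ccc4ncn(C5CCCCC5)c4c3)n2)cc1` gives 15.6%.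

Compound 4 `FC(F)(F)c1cccc(-c2cn3ccnc3c(-c3ccc4ncn(C5CCCCC5)c4c3)n2)c1` has not been measured. It differs from compound 3 in one place: 3-(trifluoromethyl)phenyl in place of 2-fluorophenyl on an aromatic carbon. The measured steps that bear on this change are those in which the group at this same position was exchanged, namely a number 2.4 percentage points lower from compound 1 to compound 2 (within the scatter), a number 8.7 percentage points lower from compound 1 to compound 3 (within the scatter) and a number 6.3 percentage points lower from compound 2 to compound 3 (within the scatter), and none of them reached beyond the scatter. Because of these steps, the move from compound 3 to compound 4 is expected to stay within the scatter as well, with no clear direction. Compound 4 is therefore estimated at 13% in this assay, between 3% and 26%, which means an expected step of a number 3.7 percentage points higher from compound 3 to compound 4 (within the scatter).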

Compound 4, a percentage reported as inhibition, at one concentration (the size of the read-out at that concentration, not a potency): 1.06%
Compound 4: the middle estimate sits 11.9 percentage points above what was measured; the measured number lies below the stated range.
By their numbers in this assay, from the lowest: compounds 4, 3, 2 and 1 (each within the scatter of the next, the first and the last beyond it).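

In this assay, within the data shown here, this position had so far given only steps within the scatter, and the 3-(trifluoromethyl)phenyl group now gives the first steps beyond it: a number 14.5 percentage points lower from compound 2 to compound 4 (beyond the scatter) and a number 16.9 percentage points lower from compound 1 to compound 4 (beyond the scatter) while a number 8.2 percentage points lower from compound 3 to compound 4 (within the scatter) remains inside it. The group at this position can therefore move the read-out by a measurable amount, although compound 4 cannot be told apart from compound 3 and all four numbers come from a single concentration. Nothing available explains this difference.

The compounds shown change the whole aromatic group at once, so the separate contributions of the trifluoromethyl group and of where it sits on the phenyl ring remain open. Also open, going by these compounds, is how an amine, a carboxylic acid or a longer chain at this position would read out.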